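The source may report more compounds than this note shows. Statements on the series, on what has been measured and on what is new or still open speak of the compounds shown alone.

Measured compounds in a functional assay for agonist activity at G protein-coupled receptor 88 (Homo sapiens), read by HTRF and cAMP accumulation; a lower number here means that less compound is needed, a higher number that more compound is needed for the effect:
compound 1, `CC(C)C[C@H](N)CN(C(=O)[C@@H]1C[C@H]1c1ccccc1)c1ccc(-c2cccnc2)cc1`: compound 1 gives 10000 nM
compound 2, `CC(C)C[C@H](N)CN(C(=O)[C@@H]1C[C@H]1c1ccccc1)c1ccc(-c2ccoc2)cc1`: compound 2 gives 2000 nM
compound 3, `COc1ccc(-c2ccc(N(C[C@@H](N)CC(C)C)C(=O)[C@@H]3C[C@H]3c3ccccc3)cc2)cc1`: compound 3 gives 330 nM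

Compound 3 stands lowest of the three: a 6.1-fold lower number from compound 2 to compound 3 (0.78 log units; beyond the scatter) and a 30-fold lower number from compound 1 to compound 3 (1.48 log units; beyond the scatter), both beyond the scatter. Compound 4, `CC(C)C[C@H](N)CN(C(=O)[C@@H]1C[C@H]1c1ccccc1)c1ccc(-c2ccccc2F)cc1`, is the next step from compound 3: 2-fluorophenyl in place of 4-methoxyphenyl on an aromatic carbon. The earlier exchanges at the same place bear on it, a 5.0-fold lower number from compound 1 to compound 2 (0.70 log units; beyond the scatter), a 6.1-fold lower number from compound 2 to compound 3 (0.78 log units; beyond the scatter) and a 30-fold lower number from compound 1 to compound 3 (1.48 log units; beyond the scatter). Compound 4 keeps one six-membered aromatic ring of carbon only at that place, as compound 3 does, so a modest step toward a higher number in this assay is expected, closer in size to a 6.1-fold lower number from compound 2 to compound 3 (0.78 log units; beyond the scatter) than to a 30-fold lower number from compound 1 to compound 3 (1.48 log units; beyond the scatter). The expected step is a 2.4-fold higher number from compound 3 to compound 4 (0.38 log units; beyond the scatter). For compound 4 the estimate is 800 nM, with a range from 250 nM to 2500 nM.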

Compound 4, half-maximal effective concentration: 1600 nM
For compound 4 the middle estimate is 2.0-fold (0.30 log units) below the measured one; measured number inside the range.
By their numbers in this assay, from the lowest: compound 3; then compounds 4 and 2 (each within the scatter of the next); then compound 1.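

Keeping one six-membered aromatic ring of carbon only at this place does not by itself hold the number down: 2-fluorophenyl in place of 4-methoxyphenyl gives a 4.8-fold higher number from compound 3 to compound 4 (0.69 log units; beyond the scatter) in the wrong direction. Compound 4 sits within the scatter of the furan-3-yl compound at a 1.3-fold lower number from compound 2 to compound 4 (0.10 log units; within the scatter) and remains clear of the pyridin-3-yl compound at a 6.3-fold lower number from compound 1 to compound 4 (0.80 log units; beyond the scatter) so ring type alone does not set the order. Nothing at hand accounts for these steps.

The exchange alters both the substituent and its ring position, and these remain unseparated. Unsubstituted phenyl and 4-fluorophenyl would divide the two.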